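This account rests on a few compounds, and the source may have more. Where it says the series, first, only, none or still open, it means among the compounds named here.

Compound 1 `CC(C)COc1cc(C(F)(F)F)ccc1CNC(=O)C(C)c1ccc(NS(C)(=O)=O)c(F)c1` gives 0.8 nM.
Compound 2 `CC(C)CCOc1cc(C(F)(F)F)ccc1CNC(=O)C(C)c1ccc(NS(C)(=O)=O)c(F)c1` gives 0.5 nM.
Compound 3 `CCCCSc1cc(C(F)(F)F)ccc1CNC(=O)C(C)c1ccc(NS(C)(=O)=O)c(F)c1` gives 1.9 nM.

These three numbers come from an assay on CHO cells for antagonist activity at transient receptor potential cation channel subfamily V member 1 (Homo sapiens), read by FLIPR; on this read-out lower numbers stand for stronger inhibition and higher numbers for weaker inhibition. Among them compound 3 stands at the highest number: against compound 1 the step is a 2.4-fold higher number from compound 1 to compound 3 (0.38 log units; beyond the scatter), and against compound 2 it is a 3.8-fold higher number from compound 2 to compound 3 (0.58 log units; beyond the scatter). The two ether compounds sit close together, as a 1.6-fold lower number from compound 1 to compound 2 (0.20 log units; within the scatter) shows, so the only shifts beyond the scatter in this small set are the two that lead to compound 3.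

Compound 4 `CC(C(=O)NCc1ccc(C(F)(F)F)cc1C1CCCCC1)c1ccc(NS(C)(=O)=O)c(F)c1` has not yet been measured. It differs from compound 3 in one place: cyclohexyl in place of butylsulfanyl on an aromatic carbon. Among the measured compounds shown here, no measured pair in this set shows a cyclohexyl group entering anywhere, so the steps at hand bear on it only indirectly. What they do show is that exchanging the group at this position has moved the number by modest amounts, and nothing larger. On that basis a modest step is expected for compound 4 in this assay, direction uncertain, with a return toward the lower numbers of the ether compounds somewhat more likely than a further rise. The expected step is a 1.3-fold lower number from compound 3 to compound 4 (0.10 log units; within the scatter). Compound 4 is estimated at 1.5 nM, with a range from 0.4 nM to 6 nM.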

Compound 4, inhibition constant: 0.6 nM
For compound 4 the middle estimate is 2.5-fold (0.40 log units) above the measured one, and the stated range covers the measured number.
By their numbers in this assay, from the lowest: compounds 2, 4 and 1 (each within the scatter of the next); then compound 3.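

In this assay there is a 3.2-fold lower number from compound 3 to compound 4 (0.50 log units; beyond the scatter), so replacing the butylsulfanyl chain with cyclohexyl, a six-membered ring of carbon only, recovers what was lost with compound 3. The earlier compounds shown here all carry a chain joined to the aromatic carbon through oxygen or sulfur, whereas compound 4 shows that this position also accepts a ring bonded directly, with no such linking atom: there is a 1.2-fold higher number from compound 2 to compound 4 (0.08 log units; within the scatter) and also a 1.3-fold lower number from compound 1 to compound 4 (0.12 log units; within the scatter), which places the cyclohexyl compound level with both ethers, so that compound 3 alone stands apart. Nothing available here explains why these groups give such similar numbers or why butylsulfanyl differs.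

The compounds shown leave open whether the sulfur or the straight chain sets compound 3 apart, since a butoxy compound, which would separate the two, is not among them. On these data alone, it also remains open how far this tolerance extends, for example to a smaller cyclopentyl ring, a flat phenyl ring, or a chain ending in an amine or a carboxylic acid.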